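Halogen position swap on the benzyl arm, cytotoxicity

A few compounds are considered here, and "the series" means these few. Any claim that something is new, unique, unknown or untested is made for them only; others in the source may bear on it.

The series shares one core, carried by compound 1 `Cc1ccc2cc(CN(Cc3ccc(F)cc3)Cc3ccc(C(C)C)cc3)c(=O)[nH]c2c1` and compound 2 `Cc1ccc2cc(CN(Cc3ccc(Cl)cc3)Cc3ccc(C(C)C)cc3)c(=O)[nH]c2c1`. In a toxicity assay on MDCK cells (Canis lupus familiaris) for cytotoxicity, read by crystal violet staining, with a stated time of 48 h (a lower number here means that less compound is tolerated, a higher number that more compound is tolerated), compound 1 gives only a limit, > 33000 nM. In this assay compound 2 likewise gives only a limit, > 33000 nM. The step that the two limits leave unreadable from compound 1 to compound 2 is therefore not readable, and compound 2 stands at the same point as compound 1: both values sit at the limit of > 33000 nM in this assay, at which 2 of the 2 values shown sit, with no number to place compound 2 beneath it.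

Compound 3 `Cc1ccc2cc(CN(Cc3ccc(C(C)C)cc3)Cc3ccccc3F)c(=O)[nH]c2c1` differs from compound 2 in one place: 2-fluorophenyl in place of 4-chlorophenyl on a saturated chain carbon bound to an amine nitrogen. Going by the values given here, the only measured step, the one from compound 1 to compound 2, is unreadable, so no measured evidence sets a size or direction for this change. The working expectation for this assay is therefore no step beyond the scatter, with compound 3 most likely again returning only a limit. The step that the limit leaves unreadable from compound 2 to compound 3 is the expected one. Compound 3 is estimated at 50000 nM, within 20000 nM to 150000 nM.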

Compound 3, half-maximal cytotoxic concentration: > 33000 nM
Compound 3 ended at the assay's limit; the forecaster's own chance of this, stated with the estimate: 80%; the middle value does not contradict the limit.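

In this assay compound 3 gives > 33000 nM as a limit of the assay, so no step among compound 1, compound 2 and compound 3 can be read: the limit of > 33000 nM in this assay, at which 3 of the 3 values shown sit.

Left open is the actual half-maximal cytotoxic concentration of each of the three compounds, and whether these halogen changes on the benzyl arm shift it at all.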